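The source may hold more compounds than are shown below. What is called first, only, known or untested is meant among the compounds shown, and "the series" means these compounds.

Compound 2 `CN(C)CCN1CCN(CC(=O)Nc2ccc(-c3nc4ccccc4o3)cc2)CC1` and compound 1 `CN(C)CCN1CCN(CC(=O)Nc2ccc(-c3nc4cc(Cl)ccc4o3)cc2)CC1` share one core and differ at a single position. In a functional assay on MCF7 cells (Homo sapiens) for cytotoxicity, read by MTT assay, with a stated time of 24 h (a higher number here means a weaker inhibitor, a lower number a stronger inhibitor), compound 2 gives 59400 nM, while compound 1 gives 7920 nM; the change between them, (chloro in place of hydrogen on an aromatic carbon), made a 7.5-fold lower number from compound 2 to compound 1 (0.88 log units; beyond the scatter). Compound 3 `Cc1cc(-c2nc3ccccc3o2)ccc1NC(=O)CCl` is built on a different core, and the difference between the two cores is not broken down here. In this assay compound 3 gives 29800 nM, a number within the scatter of that of compound 2. Compound 4 `Cc1cc(-c2nc3cc(Cl)ccc3o2)ccc1NC(=O)CCl` has not yet been measured; it carries the same change relative to compound 3, (chloro in place of hydrogen on an aromatic carbon), at the same place as in the first pair. For compound 4 a comparable step is expected, a 6.6-fold lower number from compound 3 to compound 4 (0.82 log units; beyond the scatter), resting on the earlier step of a 7.5-fold lower number from compound 2 to compound 1 (0.88 log units; beyond the scatter), though a single precedent on another core leaves the size uncertain. Compound 4 is therefore expected to give about 4500 nM in this assay, between 1500 nM and 14000 nM.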

Compound 4, half-maximal inhibitory concentration: > 100000 nM
Compound 4 gave a limit, no number; the forecaster's own chance of this, stated with the estimate: 3%; middle value at least 22-fold (1.34 log units) from the limit.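

Placed on the core of compound 3, chloro in place of hydrogen on an aromatic carbon gave an at least 3.3-fold higher number from compound 3 to compound 4 (0.52 log units; beyond the scatter) in this assay, so the step seen on the core of compound 1 did not carry over: the same change on two cores in this assay, a 7.5-fold lower number (0.88 log units; beyond the scatter) from compound 2 to compound 1 and an at least 3.3-fold higher number (0.52 log units; beyond the scatter) from compound 3 to compound 4, at least 25-fold (1.40 log units) apart, beyond the scatter of two such steps. For compound 4 the value of > 100000 nM is a limit of the assay and not a number: the limit of > 100000 nM in this assay, at which 1 of the 4 values shown sits. With one pair on each core, this shows that the change cannot be assumed to transfer within this series, but it does not show which difference between the cores matters.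

The side chains and the ring methyl of the two cores differ together, leaving their separate contributions open. On these data alone, how a carboxylic acid or a bromo group at the same place would behave on either core also remains open.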